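This account rests on a few compounds, and the source may have more. Where it says the series, first, only, none or still open, it means among the compounds named here.

Compound 3 `CCCCOC(=O)NS(=O)(=O)c1ccc(CCC)cc1-c1ccc(Cn2c(CCCC)nc3ccccc32)cc1` gives 9.2 nM in an assay on membranes from HEK293 cells for displacement of a labelled ligand from Type-2 angiotensin II receptor (Homo sapiens), read by radioligand binding; a lower number here means a stronger inhibitor, a higher number a weaker inhibitor. Among the three numbers gathered so far it sits second highest: compound 1 `CCCCOC(=O)NS(=O)(=O)c1ccc(CCC)cc1-c1ccc(Cn2c(C(C)C)nc3ccccc32)cc1` gives 4 nM, and the step of a 2.3-fold higher number from compound 1 to compound 3 (0.36 log units; beyond the scatter) is the nearest gap; compound 2 `CCCCOC(=O)NS(=O)(=O)c1ccc(CCC)cc1-c1ccc(Cn2c(C3CCCCC3)nc3ccccc32)cc1` gives 130 nM, and the step of a 14-fold lower number from compound 2 to compound 3 (1.15 log units; beyond the scatter) is the furthest. Compound 4 `CCCCOC(=O)NS(=O)(=O)c1ccc(CCC)cc1-c1ccc(Cn2c(C)nc3ccccc32)cc1` carries hydrogen in place of propyl on a saturated chain carbon bound to an aromatic carbon; read one bond further out, the change is butyl to methyl.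

All three measured steps vary the same group on an aromatic carbon of the shared core. a 33-fold higher number from compound 1 to compound 2 (1.51 log units; beyond the scatter) is large, a 2.3-fold higher number from compound 1 to compound 3 (0.36 log units; beyond the scatter) is modest, and a 14-fold lower number from compound 2 to compound 3 (1.15 log units; beyond the scatter) is large. Cyclohexyl gives the highest number, isopropyl the lowest and butyl lies close to isopropyl, with no compound going against that order. For the measured compounds named here, compound 4 moves toward a shorter group than any of these, so no measured step brackets it; the small gap between isopropyl and butyl suggests that shortening the chain further changes little. In this assay a step of no more than modest size is therefore expected, direction uncertain, and a 1.1-fold higher number from compound 3 to compound 4 (0.04 log units; within the scatter) is the expected step. Compound 4 is estimated at 10 nM, with a range from 3 nM to 40 nM.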

Compound 4, inhibition constant: 9.4 nM
Compound 4: the middle estimate sits 1.1-fold (0.03 log units) above what was measured; the range from low to high includes it.
By their numbers in this assay, from the lowest: compound 1; then compounds 3 and 4 (each within the scatter of the next); then compound 2.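

In this assay, hydrogen in place of propyl on a saturated chain carbon bound to an aromatic carbon gives a 1.0-fold higher number from compound 3 to compound 4 (0.01 log units; within the scatter), so butyl and methyl at this position cannot be told apart, and the length of an unbranched chain, across these two groups, shows no measurable effect on the number. Methyl also matches butyl in its relation to the other two groups, with a 14-fold lower number from compound 2 to compound 4 (1.14 log units; beyond the scatter) against cyclohexyl and a 2.4-fold higher number from compound 1 to compound 4 (0.37 log units; beyond the scatter) against isopropyl, which leaves isopropyl with the lowest number of the four and shows that the smallest group here does not give the lowest number. No supporting data are at hand to account for this flat stretch or for the gaps to isopropyl and cyclohexyl.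

Open, going by these compounds, is whether the flat stretch holds for a longer chain such as hexyl or for a hydrogen placed directly on the aromatic carbon. Also open, on these data alone, is whether the lower number of isopropyl extends to other small branched or cyclic groups such as tert-butyl or cyclopropyl, and how a group bearing an amine or a carboxylic acid would read at this position.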